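The source may hold more compounds than are shown below. What is called first, only, known or untested is meant among the compounds shown, and "the series" means these compounds.

Working notes on the series. Three esters share one core and differ only in the length of the saturated chain on the ester oxygen: compound 1 `CCCCCCCCCCCCCOC(=O)CCC(=O)N1CCN(CCCOc2cc3c(Nc4ccc(F)c(Cl)c4)ncnc3cc2OC)CC1`, compound 2 `CCCCCCCCCCCCCCOC(=O)CCC(=O)N1CCN(CCCOc2cc3c(Nc4ccc(F)c(Cl)c4)ncnc3cc2OC)CC1` and compound 3 `CCCCCCCCCCCCCCCCCCCOC(=O)CCC(=O)N1CCN(CCCOc2cc3c(Nc4ccc(F)c(Cl)c4)ncnc3cc2OC)CC1`. In a functional assay on A549 cells (Homo sapiens) for cytotoxicity, read by MTT assay, with a stated time of 24 h, tested at 40 uM (on this read-out lower numbers stand for a stronger effect and higher numbers for a weaker effect at the one concentration tested), compound 1 gives 71.1%, compound 2 gives 88.6% and compound 3 gives 92.3%. Compound 3 therefore stands highest of the three numbers in this assay, with compound 2 within the scatter of it and compound 1 further off, beyond the scatter.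

Compound 4 `CCCCCCCCCCCCCCCCCCCCOC(=O)CCC(=O)N1CCN(CCCOc2cc3c(Nc4ccc(F)c(Cl)c4)ncnc3cc2OC)CC1` is not yet measured in this assay. Against compound 3 it shows (methyl in place of hydrogen on a saturated chain carbon, ten or more bonds along the chain from an oxygen next to a carbonyl group). The same kind of chain growth has been seen twice: a number 17.5 percentage points higher from compound 1 to compound 2 (beyond the scatter) and a number 3.7 percentage points higher from compound 2 to compound 3 (within the scatter), with the larger jump a number 21.2 percentage points higher from compound 1 to compound 3 (beyond the scatter) spanning both. The step that starts from an already long chain, a number 3.7 percentage points higher from compound 2 to compound 3 (within the scatter), is the closer comparison, and it stayed within the scatter. For compound 4 in this assay the expected step is therefore a number 0.7 percentage points higher from compound 3 to compound 4 (within the scatter), none beyond the scatter. The estimate for compound 4 is 93%, with a range from 83% to 102%.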

Compound 4, a percentage reported as activity, at one concentration (the size of the read-out at that concentration, not a potency): 87.1%
Beside the measured number, compound 4's estimate is 5.9 percentage points above it; the measured number falls inside the stated range.
By their numbers in this assay, from the lowest: compound 1; then compounds 4, 2 and 3 (each within the scatter of the next).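

In this assay further chain growth brings no change beyond the scatter once the chain is long, with a number 5.2 percentage points lower from compound 3 to compound 4 (within the scatter) and a number 1.5 percentage points lower from compound 2 to compound 4 (within the scatter), so compounds 2, 3 and 4 cannot be told apart, while a number 16 percentage points higher from compound 1 to compound 4 (beyond the scatter) leaves compound 1 the strongest of the four at this one concentration. Methyl in place of hydrogen at this place on the chain therefore has no single size of step, and its result depends on the chain it starts from: the same change on two cores in this assay, a number 17.5 percentage points higher (beyond the scatter) from compound 1 to compound 2 and a number 5.2 percentage points lower (within the scatter) from compound 3 to compound 4, 22.7 percentage points apart, beyond the scatter of two such steps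
The hexyl change behaves the same way: the same change on two cores in this assay, a number 21.2 percentage points higher (beyond the scatter) from compound 1 to compound 3 and a number 1.5 percentage points lower (within the scatter) from compound 2 to compound 4, 22.7 percentage points apart, beyond the scatter of two such steps

From the compounds shown here alone, whether a shorter chain on the ester oxygen would lower the number further than in compound 1 remains open. So does the result for a carboxylic acid in place of the ester.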